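The compounds below may be only part of what the source reports. "The series", "measured", "known", "first", "only" and "open" are said of these compounds alone.

Measured in a functional assay on the whole organism with Rattus norvegicus as the target; on this read-out higher numbers stand for an effect only at larger amounts of compound and lower numbers for an effect already at smaller amounts:
compound 1 `CCc1nn(C)c2c1C(c1ccccc1Cl)=NCC(=O)N2` gives 32 mg/kg;
compound 2 `CCCc1nn(C)c2c1C(c1ccccc1Cl)=NCC(=O)N2` gives 250 mg/kg;
compound 3 `CCn1nc(C)c2c1NC(=O)CN=C2c1ccccc1Cl` gives 8 mg/kg.

Compound 4 `CCCn1nc(C)c2c1NC(=O)CN=C2c1ccccc1Cl` is the one still to be measured. Compound 1 and compound 2 differ by methyl in place of hydrogen on a saturated chain carbon, two bonds along the chain from an aromatic carbon, and that change gave a 7.8-fold higher number from compound 1 to compound 2 (0.89 log units; beyond the scatter). Compound 3 and compound 4 differ by methyl in place of hydrogen on a saturated chain carbon, two bonds along the chain from an aromatic nitrogen, which is the same kind of change, though the place is not identical: in the first pair the chain carbon sits two bonds from an aromatic carbon, in the second pair two bonds from an aromatic nitrogen. Compound 3 and compound 1 have the same atoms joined differently; the difference between the two cores is not broken down here. Compound 3 holds the lowest number of the three, with compound 1 as its nearest neighbour.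

For compound 4 the expectation rests on the earlier pair: because the lengthening from compound 1 to compound 2 gave a 7.8-fold higher number from compound 1 to compound 2 (0.89 log units; beyond the scatter), a step of similar direction, a 4.0-fold higher number from compound 3 to compound 4 (0.60 log units; beyond the scatter), is expected here, with extra uncertainty from the changed surroundings. Compound 4 is therefore estimated at 32 mg/kg, between 10 mg/kg and 125 mg/kg.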

Compound 4, minimum effective dose: 63 mg/kg
Beside the measured number, compound 4's estimate is 2.0-fold (0.29 log units) below it, and the stated range covers the measured number.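

In this assay, the extra methyl that turns ethyl into propyl on the core of compound 3 gives a 7.9-fold higher number from compound 3 to compound 4 (0.90 log units; beyond the scatter), so the effect now appears only at a larger dose. Set beside the earlier pair, the change carries over from one core to the other in the same direction and at about the same size, and neither pair goes against this: the same change on two cores in this assay, a 7.8-fold higher number (0.89 log units; beyond the scatter) from compound 1 to compound 2 and a 7.9-fold higher number (0.90 log units; beyond the scatter) from compound 3 to compound 4, 1.0-fold (0.00 log units) apart, within the scatter of two such steps. Among the compounds shown here, this rests on only two pairs, on two cores with the same atoms joined differently, so it shows that the step transferred here but not that it would transfer to any other core, and it does not explain why the dose rises.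

The compounds shown leave open whether a longer chain such as butyl would raise the dose further on either core. They also leave open how a branched group such as isopropyl, or a chain carrying an amine or a carboxylic acid, would behave in the same place.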